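Dropping the chloro: from compound 2 to compound 3

This account rests on a few compounds, and the source may have more. Where it says the series, first, only, none or still open, it means among the compounds named here.

Measured so far:
Compound 1, `CC(O)(CS(=O)(=O)c1ccc(Cl)cc1)c1nc(-c2ccc([N+](=O)[O-])c(C(F)(F)F)c2)no1` — 91000 nM
Compound 2, `CC(O)(CS(=O)(=O)c1ccc(F)cc1)c1nc(-c2ccc(Cl)cc2)no1` — reported only as a limit, > 100000 nM

Both compounds were tested in a functional assay on DU-145 cells (Homo sapiens) for cytotoxicity, read by MTT assay; on this read-out higher numbers stand for weaker inhibition and lower numbers for stronger inhibition. Compound 1 gives a measured number, 91000 nM, which is itself weak. Compound 2 stands differently: for compound 2 this assay reports no number, only a limit, > 100000 nM. That limit is the edge of what the assay can read, described by the limit of > 100000 nM in this assay, at which 1 of the 2 values shown sits, so compound 2 is the weaker of the two as far as the data can tell, and how much weaker is not known.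

Compound 3, `CC(O)(CS(=O)(=O)c1ccc(F)cc1)c1nc(-c2ccccc2)no1`, keeps the whole shared core of compound 2 and changes one thing: hydrogen in place of chloro on an aromatic carbon. Going by the values given here, no pair of measured compounds shows this kind of step, so there is no measured guide for its size. Since compound 2 already sits at the limit, the expected step from compound 2 to compound 3 is none beyond the scatter, a step that the limit leaves unreadable from compound 2 to compound 3. Compound 3 is therefore expected to show 150000 nM in this assay, with a range from 60000 nM to 400000 nM, and most likely to be reported as a limit again.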

Compound 3, half-maximal inhibitory concentration: > 100000 nM
Compound 3 was reported as a limit; the forecaster's own chance of this, stated with the estimate: 75%; the middle value does not contradict the limit.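

Compound 2 and compound 3 are both reported only as limits in this assay, so no new step can be read between them. The compounds shown leave open whether going from 4-chlorophenyl to phenyl changes the cytotoxicity at all, and how weak either compound really is: the limit of > 100000 nM in this assay, at which 2 of the 3 values shown sit.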